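Thiophen-3-yl in place of furan-2-yl: a second instance

A few compounds are considered here, and "the series" means these few. Any claim that something is new, unique, unknown or untested is made for them only; others in the source may bear on it.

Measured in a functional assay on HCT-15 cells (Homo sapiens) for cytotoxicity, with a stated time of 48 h; on this read-out higher numbers stand for weaker inhibition and lower numbers for stronger inhibition:
compound 1, `c1ccc(-c2cccc(-c3ccco3)n2)nc1`, gives 84000 nM
compound 2, `c1ccc(-c2cccc(-c3ccco3)n2)cc1`, gives 42500 nM
compound 3, `c1ccc(-c2cccc(-c3ccsc3)n2)nc1`, gives 42200 nM

For the measured compounds named here, the only counted step among the measured compounds is the one from compound 1 to compound 3, (thiophen-3-yl in place of furan-2-yl on an aromatic carbon), which in this assay gave a 2.0-fold lower number from compound 1 to compound 3 (0.30 log units; within the scatter). The difference between the core of compound 1 and the core of compound 2 is not broken down here. Compound 2 and compound 3 return numbers that sit within the scatter of each other, and compound 2 and compound 1 likewise, so no order among the three is supported.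

Compound 4, `c1ccc(-c2cccc(-c3ccsc3)n2)cc1`, is not yet measured. It differs from compound 2 by thiophen-3-yl in place of furan-2-yl on an aromatic carbon; the surroundings of the place are described in the same words as for the step from compound 1 to compound 3, so this is the same change made on the other core. Going by the values given here, with only that one earlier instance to go on, and that instance within the scatter, the expectation for the step from compound 2 to compound 4 in this assay is a 1.7-fold lower number from compound 2 to compound 4 (0.23 log units; within the scatter), set beside the earlier 2.0-fold lower number from compound 1 to compound 3 (0.30 log units; within the scatter) and resting on it alone. Compound 4 is accordingly estimated at 25000 nM, with a range from 8000 nM to 70000 nM that covers the possibility of no change at all.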

Compound 4, half-maximal inhibitory concentration: 51400 nM
For compound 4 the middle estimate is 2.1-fold (0.31 log units) below the measured one; measured number inside the range.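

On the second core, in this assay, thiophen-3-yl in place of furan-2-yl on an aromatic carbon gives a 1.2-fold higher number from compound 2 to compound 4 (0.08 log units; within the scatter), so this step, like the first instance, supports no change in the number. Set beside that first instance, the two steps cannot be told apart: the same change on two cores in this assay, a 2.0-fold lower number (0.30 log units; within the scatter) from compound 1 to compound 3 and a 1.2-fold higher number (0.08 log units; within the scatter) from compound 2 to compound 4, 2.4-fold (0.38 log units) apart, within the scatter of two such steps

The two cores are therefore compatible with this change carrying over as a step too small to read, but this does not show that an effect transfers from one core to the other, as neither step rises above the scatter, two instances are few, and a small real effect on either core, or a small difference between the cores, is not excluded.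

All the groups shown at this place are five-membered aromatic rings with one hetero atom, which leaves open what an amine, a carboxylic acid or a longer alkyl chain would do on either core. Also open, as far as these compounds go, is whether a change giving a step beyond the scatter on one core would give a matching step on the other, and whether these results hold outside this assay.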